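This account rests on a few compounds, and the source may have more. Where it says the series, first, only, none or still open, it means among the compounds named here.

Three compounds have so far been measured in an assay on isolated protein for inhibition of protein deacetylase HDAC6 (Homo sapiens); on this read-out higher numbers stand for weaker inhibition and lower numbers for stronger inhibition:

compound 1 `Cc1ccc(-c2noc(-c3ccc(C(=O)C(F)(F)F)s3)n2)cc1` gives 860 nM
compound 2 `O=C(c1ccc(-c2nc(Cc3cccs3)no2)s1)C(F)(F)F` gives 170 nM
compound 3 `O=C(c1ccc(-c2nc(-c3ccc(Cl)cc3Cl)no2)s1)C(F)(F)F` gives 3000 nM

Among these three, compound 1 sits in the middle: compound 2 gives a lower number, and compound 3 a higher one, both separated from compound 1 by more than the usual scatter. The shared core carries a trifluoromethyl ketone at one end and a variable group at the other, and all measured steps change that variable group as a whole: a 5.1-fold lower number from compound 1 to compound 2 (0.70 log units; beyond the scatter), a 3.5-fold higher number from compound 1 to compound 3 (0.54 log units; beyond the scatter), and an 18-fold higher number from compound 2 to compound 3 (1.25 log units; beyond the scatter).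

Compound 4 `CC(C)(C)c1ccc(-c2noc(-c3ccc(C(=O)C(F)(F)F)s3)n2)cc1` differs from compound 1 in a smaller way: tert-butyl in place of methyl on an aromatic carbon. Within the data shown here, none of the measured steps touches only a substituent on the 4-methylphenyl group, so no step speaks directly to this change. The steps do show that the distal group can move the number in this assay by a modest to large amount in either direction, but a swap of one small alkyl group for a larger one at the same place is a gentler change than replacing the whole ring. A small step, possibly within the scatter, is therefore expected for compound 4: a 1.2-fold higher number from compound 1 to compound 4 (0.07 log units; within the scatter), and its value in this assay is estimated at 1000 nM, within a range from 400 nM to 2500 nM.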

Compound 4, half-maximal inhibitory concentration: 3540 nM
Beside the measured number, compound 4's estimate is 3.5-fold (0.55 log units) below it, outside the stated range (above it).
By their numbers in this assay, from the lowest: compound 2; then compound 1; then compounds 3 and 4 (each within the scatter of the next).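

Among these compounds, this is the first step in the set that leaves the ring in place and changes only the group on it, para to a large group: tert-butyl in place of methyl gives a 4.1-fold higher number from compound 1 to compound 4 (0.61 log units; beyond the scatter) in this assay. The earlier steps shown here replaced the whole variable group, so they could not show that this single place matters on its own; the change here, from a group of 1 heavy atom to one of 4 heavy atoms with no ring, hydrogen-bond donor, hydrogen-bond acceptor or net charge on either side, is enough to weaken inhibition beyond the scatter. It also brings compound 4, at 3540 nM, within the scatter of compound 3, at 3000 nM, so this one substituent change reaches the same level as the swap to 2,4-dichlorophenyl. No measurement given here accounts for the weaker inhibition.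

On these data alone, it remains open whether the number climbs step by step through ethyl and isopropyl or changes only on reaching tert-butyl. As far as these compounds go, how an amine or a carboxylic acid at this same place would read also remains open.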